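Swapping Benzylamino for Hydroxy on a Shared Core

The source may hold more compounds than are shown below. What is called first, only, known or untested is meant among the compounds shown, and "the series" means these compounds.

Compound 1 `C=CC1=C(C(=O)NCc2ccccc2)C(c2ccc(OC)c(OC)c2)OC1` gives > 100000 nM in a functional assay on SW480 cells (Homo sapiens) for cytotoxicity, read by MTT assay, with a stated time of 24 h; on this read-out higher numbers stand for weaker inhibition and lower numbers for stronger inhibition.
Compound 2 `C=CC1=C(C(=O)O)C(c2ccc(OC)c(OC)c2)OC1` gives > 100000 nM in this assay.
Compound 3 `C=CC1=C(C(=O)NCc2ccccc2)C(c2ccc(Cl)c(Cl)c2)OC1` gives > 100000 nM in this assay.

Each of these three results is a limit of the assay rather than a number. The value of compound 1 is a limit. The value of compound 2 is a limit. The value of compound 3 is a limit. All three sit at the limit of > 100000 nM in this assay, at which 3 of the 3 values shown sit.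

Compound 1 and compound 2 differ by one change, (hydroxy in place of benzylamino on a carbonyl carbon). With both ends at the limit, the size of this step cannot be read: a step that the two limits leave unreadable from compound 1 to compound 2.

Compound 4 `C=CC1=C(C(=O)O)C(c2ccc(Cl)c(Cl)c2)OC1` has not yet been measured in this assay. It differs from compound 3 by the same change, (hydroxy in place of benzylamino on a carbonyl carbon), made at the same place on the carbonyl carbon. The difference between the two cores, that of compound 1 and that of compound 3, is not broken down here.

From compound 3 to compound 4 a step that the limit leaves unreadable from compound 3 to compound 4 is expected, beside the unreadable earlier one, a step that the two limits leave unreadable from compound 1 to compound 2. That expectation rests on compound 3, whose value > 100000 nM is a limit. It also rests on compound 2, whose value > 100000 nM is a limit after the same change. Compound 4 is estimated at 150000 nM, between 50000 nM and 500000 nM, and most likely will again be reported only as a limit.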

Compound 4, half-maximal inhibitory concentration: > 100000 nM
Compound 4 gave a limit, no number; the forecaster's own chance of this, stated with the estimate: 85%; the middle value does not contradict the limit.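

In this assay compound 4 gives > 100000 nM, which is a limit and not a number. On these data alone, no new step can be read: compound 3 and compound 4 both stand at a limit, so the size of the change between them stays unknown. The compounds shown leave open whether swapping benzylamino for hydroxy, or the difference between the two cores, alters the result in this assay, as every result is a limit: the limit of > 100000 nM in this assay, at which 4 of the 4 values shown sit.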